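Sulfonyl aryl swap on the shared core: clearance outlook

The source may hold more compounds than are shown below. What is called first, only, known or untested is meant among the compounds shown, and "the series" means these compounds.

In an ADME assay on microsomes from liver (Homo sapiens) for metabolic stability, tested at 2.5 uM (on this read-out lower numbers stand for slow clearance and higher numbers for fast clearance), compound 3 `O=S(=O)(c1cc(Cl)cc(Cl)c1)c1cnc2cc(F)ccc2c1-c1ccc(F)cc1` gives 0.18 mL/min, placing it second highest of the three numbers; compound 1 `O=S(=O)(c1cc(Cl)cc(Cl)c1)c1cnc2cc(F)ccc2c1-c1ccc(Cl)cc1` gives 0.13 mL/min, and compound 2 `COc1ccc(-c2c(S(=O)(=O)c3ccc(OC)cc3)cnc3cc(F)ccc23)cc1` gives 1.18 mL/min, a higher number than compound 3 beyond the scatter. For the measured compounds named here, the only single-point step measured, a 1.4-fold higher number from compound 1 to compound 3 (0.14 log units; within the scatter), concerns the other aryl ring and does not touch the sulfonyl aryl. Compound 4 `COc1ccc(S(=O)(=O)c2cnc3cc(F)ccc3c2-c2ccc(F)cc2)cc1` differs from compound 3 by 4-methoxyphenyl in place of 3,5-dichlorophenyl on a sulfonyl sulfur. Compound 2 carries the same 4-methoxyphenyl on its sulfonyl sulfur together with a second change, so it only brackets the outcome. A move towards the number of compound 2 is expected, a 3.1-fold higher number from compound 3 to compound 4 (0.49 log units; beyond the scatter), and compound 4 is estimated at 0.55 mL/min, between 0.22 mL/min and 1.4 mL/min in this assay.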

Compound 4, intrinsic clearance in a liver preparation (reported as CLH), per the amount of preparation that the assay uses: 1.71 mL/min
Beside the measured number, compound 4's estimate is 3.1-fold (0.49 log units) below it; measured number above the stated range.
By their numbers in this assay, from the lowest: compounds 1 and 3 (each within the scatter of the next); then compounds 2 and 4 (each within the scatter of the next).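

At the sulfonyl sulfur, 4-methoxyphenyl in place of 3,5-dichlorophenyl gives a step beyond the scatter in this assay (a 9.5-fold higher number from compound 3 to compound 4 (0.98 log units; beyond the scatter)), so clearance in this series responds strongly to the sulfonyl aryl. Fluoro in place of methoxy on the other aryl ring stays within the scatter (a 1.4-fold higher number from compound 2 to compound 4 (0.16 log units; within the scatter)), as does the fluoro-for-chloro step (a 1.4-fold higher number from compound 1 to compound 3 (0.14 log units; within the scatter)). Nothing available explains the size of the sulfonyl aryl step.

Still open, on these data alone, is whether the step follows the methoxy entering or the two chlorines leaving. Plain phenyl or a pyridine ring on the sulfonyl sulfur could separate these.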